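Toxicity notes: from compound 2 to compound 4

A few compounds are considered here, and "the series" means these few. Any claim that something is new, unique, unknown or untested is made for them only; others in the source may bear on it.

Of the compounds shown here, three have been read in a toxicity assay on THP-1 cells (Homo sapiens) for inhibition; on this read-out higher numbers stand for lower toxicity in this test and lower numbers for higher toxicity in this test: compound 1 (`Cn1c(-c2ccccc2)cnc1NC(=O)c1ccc(F)cc1`), compound 2 (`COc1ccc(-c2cnc(NC(=O)c3ccccc3O)n2C)cc1`) and compound 3 (`COc1ccc(-c2cnc(NC(=O)c3cccc([N+](=O)[O-])c3)n2C)cc1`). Compound 1 gives > 100000 nM, which is a limit of the assay. Compound 3 gives > 100000 nM, also a limit. Compound 2 gives > 100000 nM, likewise a limit and not a number. All three therefore sit together, with no order among them: the limit of > 100000 nM in this assay, at which 3 of the 3 values shown sit.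

Compound 4 (`COc1ccc(-c2cnc(NC(=O)c3ccco3)n2C)cc1`) has not yet been measured. It carries furan-2-yl in place of 2-hydroxyphenyl on a carbonyl carbon. For the measured compounds named here, no measured pair shows a change at this place.

In this assay, no change beyond the usual scatter and no particular direction is expected for a number no higher from compound 2 to compound 4 (the limit leaves the size open). This expectation rests on compound 2 and its limit of > 100000 nM. For compound 4 the estimated value is 100000 nM, with an expected range from 50000 nM to 200000 nM.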

Compound 4, half-maximal cytotoxic concentration: > 100000 nM
Compound 4: a limit, no number; the forecaster's own chance of this, stated with the estimate: 85%; the middle value lies on the limit itself.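

Compound 4 gives > 100000 nM in this assay, a limit and not a number. Compound 2 also stands at a limit, so no step can be read between compound 2 and compound 4. The compounds shown leave open which structural change, if any, would give a number rather than a limit in this assay.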